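Furan-2-yl in Place of Thiophen-2-yl: An Expected Flat Step

The source may report more compounds than this note shows. Statements on the series, on what has been measured and on what is new or still open speak of the compounds shown alone.

Compound 1 `CC(C)(C)Cc1c(-c2cccc(F)c2F)sc(N)c1C(=O)c1ccc(Cl)cc1` gives 1% in an assay on CHO cells for displacement of a labelled ligand from adenosine receptor A3 (Homo sapiens), read by scintillation counting, tested at 10 uM; a higher number here means more inhibition at the concentration tested (going by the name of the read-out), a lower number less inhibition.
Compound 2 `CC(C)(C)Cc1c(-c2cccs2)sc(N)c1C(=O)c1ccc(Cl)cc1` gives 1% in this assay.

Compound 2 stands level with compound 1 at the digits shown; the step of no change at the digits printed from compound 1 to compound 2 (within the scatter) lies within the scatter. Compound 3 `CC(C)(C)Cc1c(-c2ccco2)sc(N)c1C(=O)c1ccc(Cl)cc1` differs from compound 2 by furan-2-yl in place of thiophen-2-yl on an aromatic carbon. Going by the values given here, no measured step covers this exact exchange, and the one step that bears on it, the exchange of the ring at the same place from compound 1 to compound 2, was flat. Compound 3 is therefore expected to show a step of a number 1 percentage points higher from compound 2 to compound 3 (within the scatter) in this assay, none beyond the scatter. Compound 3 is estimated at 2%, expected between 0% and 14%.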

Compound 3, a percentage reported as inhibition, at one concentration (the size of the read-out at that concentration, not a potency): 1%
The estimate for compound 3 lay 1 percentage points above the measured number; measured number inside the range.
By their numbers in this assay, from the lowest: compounds 1, 2 and 3 (each within the scatter of the next).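

In this assay, furan-2-yl in place of thiophen-2-yl gives no change at the digits printed from compound 2 to compound 3 (within the scatter), and furan-2-yl in place of 2,3-difluorophenyl gives no change at the digits printed from compound 1 to compound 3 (within the scatter). The flat reading at this aromatic carbon next to the ring sulfur therefore now spans three rings, and it also holds for an exchange of the hetero atom, sulfur for oxygen, within a five-membered aromatic ring. Nothing available explains this flatness.

The compounds shown leave open whether an amine or a carboxylic acid on this carbon would move the number. They also leave open whether these exchanges stay flat with a longer chain in place of the neopentyl group.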